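Swapping an Acid for a Tetrazole in Leukotriene Antagonists

The compounds below may be only part of what the source reports. "The series", "measured", "known", "first", "only" and "open" are said of these compounds alone.

Of the compounds shown here, two have been tested in an in vivo functional assay on the whole organism (Rattus norvegicus) with cysteinyl leukotriene receptor (Homo sapiens) as the target; a higher number here means that more compound is needed for the effect, a lower number that less compound is needed. Compound 1 `CCCc1c(COc2ccc(C(=O)CCCC(=O)O)cc2)ccc(C(C)=O)c1O` gives 9.5 mg/kg, while compound 2 `CCc1c(COc2ccc(C(=O)CC(C)(C)CC(=O)O)cc2)ccc(C(C)=O)c1O` gives 1.4 mg/kg, the lower of the two numbers by a gap beyond the usual scatter. Compound 3 `CCc1c(COc2ccc(C(=O)CC(C)(C)Cc3nnn[nH]3)cc2)ccc(C(C)=O)c1O` differs from compound 2 in one place: 1H-tetrazol-5-yl in place of carboxy on a saturated chain carbon, three bonds along the chain from a carbonyl carbon. Within the data shown here, no pair of measured compounds that differ only in this exchange is available to gauge it. The exchange is expected to give a modest step, a 1.4-fold lower number from compound 2 to compound 3 (0.15 log units; within the scatter), within the scatter and if anything toward a lower number. Compound 3 is estimated at 1 mg/kg in this assay, with a range from 0.3 mg/kg to 4 mg/kg.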

Compound 3, dose for half-maximal effect: 1.1 mg/kg
The estimate for compound 3 lay 1.1-fold (0.04 log units) below the measured number; low and high end bracket the measured number.
By their numbers in this assay, from the lowest: compounds 3 and 2 (each within the scatter of the next); then compound 1.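

In this assay, 1H-tetrazol-5-yl can stand in for carboxy on this saturated chain carbon with no change that can be told from scatter: the step, a 1.3-fold lower number from compound 2 to compound 3 (0.10 log units; within the scatter), is small. So in this pair, the carboxy group is not the only chain end that gives a number in this range. Nothing measured here speaks to why the two groups read alike.

As far as these compounds go, whether an amide or a longer chain ending in carboxy would fit this place as well remains open. So does whether the same exchange would hold on the chain of compound 1.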